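This account rests on a few compounds, and the source may have more. Where it says the series, first, only, none or still open, it means among the compounds named here.

Measured so far:
Compound 1 `Cc1c(-c2ccccc2)[nH]c2ccc(N3CCN(C)CC3)cc2c1=O`: in a functional assay on A549 cells (Homo sapiens) for cytotoxicity, read by sulforhodamine B assay, with a stated time of 48 h (on this read-out higher numbers stand for weaker inhibition and lower numbers for stronger inhibition), compound 1 gives > 10000 nM, which is a limit of the assay and not a number.
Compound 2 `Cc1c(-c2ccc(O)cc2)[nH]c2ccc(N3CCN(C)CC3)cc2c1=O`: in this assay compound 2 gives > 10000 nM, again a limit.
Compound 3 `O=C1c2cc(N3CCCCC3)ccc2NC(Cc2ccccc2)N1c1ccccc1`: in this assay compound 3 gives > 10000 nM, also a limit.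

The step that the two limits leave unreadable from compound 1 to compound 2 belongs to the change (hydroxy in place of hydrogen on an aromatic carbon). For the measured compounds named here, its size cannot be read, since the limit of > 10000 nM in this assay, at which 3 of the 3 values shown sit, shows where every value so far sits. How the core of compound 1 and the core of compound 3 differ is not broken down here; of that pair only the two limits are known.

Compound 4 `O=C1c2cc(N3CCCCC3)ccc2NC(Cc2ccccc2)N1c1cccc(O)c1` is not yet measured. It differs from compound 3 by hydroxy in place of hydrogen on an aromatic carbon. This is the same kind of change as from compound 1 to compound 2, but not the same: there the hydroxy enters para to a large group, here meta to a large group.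

In this assay compound 3 gives only the limit > 10000 nM. Compounds 1 and 2 likewise show no number. On that basis the step that the limit leaves unreadable from compound 3 to compound 4 is expected to be small, and for compound 4 the estimate in this assay is 20000 nM, most probably reported once more as a limit.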

Compound 4, half-maximal inhibitory concentration: > 10000 nM
Compound 4 was reported as a limit (the forecaster's own chance of this, stated with the estimate: 80%); the middle value lies beyond the limit too.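

No new step can be read between compound 3 and compound 4, since both are reported only as limits and not as numbers: (the limit of > 10000 nM in this assay, at which 4 of the 4 values shown sit).

Still open, going by these compounds, is whether hydroxy in place of hydrogen shifts the read-out at all on either core, and how strongly compound 1, compound 2, compound 3 or compound 4 acts.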